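Octylsulfonamido benzoic acids: swapping the biaryl for a phenethyl

The compounds below may be only part of what the source reports. "The series", "measured", "known", "first", "only" and "open" are said of these compounds alone.

Compound 1 `CCCCCCCCS(=O)(=O)Nc1cc(-c2ccccc2Cl)ccc1C(=O)O`: 26900 nM
Compound 2 `CCCCCCCCS(=O)(=O)Nc1cc(-c2cccc(F)c2)ccc1C(=O)O`: 32600 nM
Compound 3 `CCCCCCCCS(=O)(=O)Nc1ccc(-c2cccc(Cl)c2)cc1C(=O)O`: 8900 nM

These three compounds were examined in an assay on mitochondria (strain BALB/c) for inhibition of glycerol-3-phosphate acyltransferase 1, mitochondrial (Mus musculus), read by scintillation counting, with a stated time of 10 min; a higher number here means a weaker inhibitor, a lower number a stronger inhibitor. Compound 2 shows the highest number of the three; compound 1 sits nearest with a 1.2-fold higher number from compound 1 to compound 2 (0.08 log units; within the scatter), while compound 3 sits furthest, its value being well outside the scatter from compound 2. Compound 4 `CCCCCCCCS(=O)(=O)Nc1cc(CCc2ccc(OC)cc2)ccc1C(=O)O` differs from compound 2 by 2-(4-methoxyphenyl)ethyl in place of 3-fluorophenyl on an aromatic carbon, placed meta to a large group and para to the carboxy group. Among the measured compounds shown here, no measured step covers this kind of change: the only single-point step, from compound 1 to compound 2, swaps one substituted phenyl for another and lies within the scatter. The inference for this assay therefore rests on little, and no step beyond the scatter is expected, a 1.6-fold lower number from compound 2 to compound 4 (0.21 log units; within the scatter). Compound 4 is estimated at 20000 nM, with a range from 6000 nM to 65000 nM.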

Compound 4, half-maximal inhibitory concentration: 43000 nM
Compound 4: the middle estimate sits 2.2-fold (0.33 log units) below what was measured; the range from low to high includes it.
By their numbers in this assay, from the lowest: compound 3; then compounds 1, 2 and 4 (each within the scatter of the next).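

In this assay, 2-(4-methoxyphenyl)ethyl at this place, meta to a large group and para to a carboxy group, gives a 1.3-fold higher number from compound 2 to compound 4 (0.12 log units; within the scatter) and a 1.6-fold higher number from compound 1 to compound 4 (0.20 log units; within the scatter). The earlier step only traded one substituted phenyl for another, whereas this change brings in an ethyl link, more heavy atoms and a hydrogen-bond acceptor without a step beyond the scatter. Nothing available gives a reason for this result. Still open, on these data alone, is whether an amine in place of the methoxy group, or a longer chain in place of the ethyl link, would move the number beyond the scatter.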